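The source may hold more compounds than are shown below. What is called first, only, known or untested is meant among the compounds shown, and "the series" means these compounds.

Compound 2 `CN(C)C(=O)c1cc2cnc(Nc3ccc(NC(=O)C4(C(=O)Nc5cccc(C(F)(F)F)c5)CC4)cc3)nc2n1C1CCCC1` holds the lower of the two numbers measured in a functional assay on A549 cells (Homo sapiens) for inhibition, read by CCK-8 assay, with a stated time of 72 h, tested at 1 uM (a lower number here means less inhibition of growth, a higher number more inhibition of growth at the concentration tested), where compound 2 gives 15.7%, while compound 1 `CN(C)C(=O)c1cc2cnc(Nc3ccc(NC(=O)C4(C(=O)Nc5ccccc5)CC4)cc3)nc2n1C1CCCC1` gives 75%. For the measured compounds named here, the only measured step, a number 59.3 percentage points lower from compound 1 to compound 2 (beyond the scatter), is the one that bears on what follows. Compound 3 `CN(C)C(=O)c1cc2cnc(Nc3ccc(NC(=O)C4(C(=O)Nc5cccc(Br)c5)CC4)cc3)nc2n1C1CCCC1` differs from compound 2 by bromo in place of trifluoromethyl on an aromatic carbon. Because a number 59.3 percentage points lower from compound 1 to compound 2 (beyond the scatter) was large and the new change again alters the same aromatic carbon, part of that loss is expected to return, an upward step of a number 24.3 percentage points higher from compound 2 to compound 3 (beyond the scatter). Compound 3 is therefore estimated at 40%, within 15% to 70%.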

Compound 3, percent growth inhibition at one concentration: 20.2%
Compound 3: the middle estimate sits 19.8 percentage points above what was measured; measured number inside the range.
By their numbers in this assay, from the lowest: compounds 2 and 3 (each within the scatter of the next); then compound 1.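

In this assay, bromo in place of trifluoromethyl gives a number 4.5 percentage points higher from compound 2 to compound 3 (within the scatter) and bromo in place of hydrogen gives a number 54.8 percentage points lower from compound 1 to compound 3 (beyond the scatter) here. The large loss is therefore not confined to trifluoromethyl: on this aromatic carbon, a group of one heavy atom and a group of four both leave compound 2 and compound 3 well apart from compound 1. Nothing measured here explains this loss. Going by these compounds, whether an amine or a carboxylic acid on this carbon would also give a low number remains open, as does how either group would behave elsewhere on this ring.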